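This account rests on a few compounds, and the source may have more. Where it says the series, first, only, none or still open, it means among the compounds named here.

Compound 1 `O=C(CSc1nnc(-c2ccncc2)n1-c1ccccc1)N/N=C/c1cccc(F)c1`: > 50000 nM
Compound 2 `O=C(CSc1nnc(-c2ccncc2)n1-c1ccccc1)N/N=C/c1cc(Br)ccc1O`: 6460 nM

Both compounds were tested in a functional assay on MCF7 cells (Homo sapiens) for inhibition, read by MTT assay, with a stated time of 48 h; on this read-out higher numbers stand for weaker inhibition and lower numbers for stronger inhibition. The entry for compound 1, > 50000 nM, is a limit of the assay and not a number. Going by the values given here, compound 2, at 6460 nM, holds the only true number so far, so it cannot yet be ranked against a second measured value.

The next compound is compound 3 `O=C(CSc1nnc(-c2ccncc2)n1-c1ccccc1)N/N=C/c1cc(Br)cc(Br)c1O`. It differs from compound 2 by a single change: bromo in place of hydrogen on an aromatic carbon. This places bromo in place of hydrogen on an aromatic carbon, turning 5-bromo-2-hydroxyphenyl into 3,5-dibromo-2-hydroxyphenyl.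

Among the compounds with values here, only one measured step bears on this, and only indirectly: an at least 7.7-fold lower number from compound 1 to compound 2 (0.88 log units; beyond the scatter), on exchanging 3-fluorophenyl for 5-bromo-2-hydroxyphenyl. That exchange brought in a bromo and a hydroxy group together, so it does not show what a bromo adds alone. One added bromo is a smaller change than the exchange that gave compound 2 its 6460 nM, so a smaller step is expected in this assay, leaning towards a lower number and perhaps not beyond the scatter. The expected move is a 1.6-fold lower number from compound 2 to compound 3 (0.21 log units; within the scatter). Compound 3 is estimated at 4000 nM, within an expected range of 1500 nM to 15000 nM.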

Compound 3, half-maximal inhibitory concentration: 8440 nM
The estimate for compound 3 lay 2.1-fold (0.32 log units) below the measured number; low and high end bracket the measured number.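

In this assay, the added bromo, on the aromatic carbon ortho to a hydroxy group and meta to a bromo group, gives a 1.3-fold higher number from compound 2 to compound 3 (0.12 log units; within the scatter), so at this position the exchange of hydrogen for bromo shows no change that can be told from the scatter. The earlier compounds had shown only a bromo and a hydroxy group entering together, and this is the first reading of a bromo entering alone. The exchange of 3-fluorophenyl for 3,5-dibromo-2-hydroxyphenyl gives an at least 5.9-fold lower number from compound 1 to compound 3 (0.77 log units; beyond the scatter), so the separation from compound 1 remains beyond the scatter with the second bromo in place, though the size of that step is only a bound, as compound 1 stands at a limit of the assay and not at a number: the limit of > 50000 nM in this assay, at which 1 of the 3 values shown sits.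

As far as these compounds go, what the hydroxy group contributes apart from the bromo stays open. Also open, from the compounds shown here alone, is whether a methoxy group in place of that hydroxy group, or a chloro or methyl group in place of the second bromo, would stay within the scatter of compound 2.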